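The source may report more compounds than this note shows. Statements on the series, on what has been measured and on what is new or still open speak of the compounds shown alone.

Compound 2 `ClCc1ccccc1Cn1cnc2c(Cl)ncnc21` and compound 1 `ClCc1ccccc1Cn1cnc2c(Cl)nc(Cl)nc21` were both tested in a functional assay on SK-MEL-5 cells (Homo sapiens) for cytotoxicity, read by sulforhodamine B assay, with a stated time of 48 h; a higher number here means a weaker inhibitor of growth, a lower number a stronger inhibitor of growth. Compound 2 gives 2880 nM, while compound 1 gives 1540 nM. The change between them is chloro in place of hydrogen on an aromatic carbon, and it produced a 1.9-fold lower number from compound 2 to compound 1 (0.27 log units; within the scatter). Compound 3 `ClCc1cccc(Cn2cnc3ncnc(Cl)c32)c1` has the same atoms as compound 2, joined differently; the difference between the two cores is not broken down here. In this assay compound 3 gives 18200 nM, the highest of the three numbers and clearly apart from the other two. Compound 4 `ClCc1cccc(Cn2cnc3nc(Cl)nc(Cl)c32)c1` differs from compound 3 by chloro in place of hydrogen on an aromatic carbon, the same change as that from compound 2 to compound 1. Among the compounds with values here, compound 4 is expected to show a 1.9-fold lower number from compound 3 to compound 4 (0.28 log units; within the scatter), a step of the earlier size, because a 1.9-fold lower number from compound 2 to compound 1 (0.27 log units; within the scatter) is the only guide to this change. Compound 4 is therefore estimated at 9500 nM, within 4000 nM to 22000 nM.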

Compound 4, concentration for total growth inhibition: 2450 nM
Estimate against measurement, compound 4: 3.9-fold (0.59 log units) above; the whole stated range lies above it.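

On the second core, the chloro group gives a 7.4-fold lower number from compound 3 to compound 4 (0.87 log units; beyond the scatter) in this assay. The same change therefore does not have one fixed size in this series, and a step measured on one core is a poor guide to the step on the other: the same change on two cores in this assay, a 1.9-fold lower number (0.27 log units; within the scatter) from compound 2 to compound 1 and a 7.4-fold lower number (0.87 log units; beyond the scatter) from compound 3 to compound 4, 4.0-fold (0.60 log units) apart, beyond the scatter of two such steps. Within the data shown here, only two pairs stand behind this comparison, so it does not show which feature of the cores sets the size of the step, or what the change would do on a further core.

The compounds shown carry only hydrogen or chloro on the aromatic carbon between two ring nitrogen atoms, so it remains open how an amine or a methoxy group would behave there. Also open, going by these compounds, is whether such groups would show the same gap between the two cores.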